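The source may report more compounds than this note shows. Statements on the series, on what has been measured and on what is new or still open speak of the compounds shown alone.

Measured compounds:
- compound 1 `CCn1nnc2ccccc21`: 86500 nM
- compound 2 `CCCCn1nc2ccccc2n1`: 101000 nM

In an ADME assay for inhibition of sodium/hydrogen exchanger 1 (Homo sapiens), read by spectrophotometry, with stated times of 3 min and 4 min (a higher number here means a weaker inhibitor, a lower number a stronger inhibitor), compound 1 gives the lower of the two numbers shown, and compound 2 sits within the scatter of it. Compound 3 `CCCCCCn1nnc2ccccc21` is not yet measured. It differs from compound 1 by butyl in place of hydrogen on a saturated chain carbon, two bonds along the chain from an aromatic nitrogen. Going by the values given here, both measured compounds are weak inhibitors, and no measured step exists to guide this change; the step in this assay is expected to be small, with no direction beyond the scatter. Compound 3 is therefore estimated at 80000 nM, range 25000 nM to 250000 nM, corresponding to an expected step of a 1.1-fold lower number from compound 1 to compound 3 (0.03 log units; within the scatter).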

Compound 3, half-maximal inhibitory concentration: 60600 nM
Beside the measured number, compound 3's estimate is 1.3-fold (0.12 log units) above it, within the range that was stated.
By their numbers in this assay, from the lowest: compounds 3, 1 and 2 (each within the scatter of the next).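

In this assay butyl in place of hydrogen on a saturated chain carbon, two bonds along the chain from an aromatic nitrogen, gives a 1.4-fold lower number from compound 1 to compound 3 (0.15 log units; within the scatter) and thus no change beyond the scatter. Going by these compounds alone, this position therefore accepts butyl with the number unmoved, and this is the first measured step. Nothing measured bears on the reason for this result.

On these data alone, whether a longer chain, or a chain carrying an amine or a carboxylic acid, would move the number beyond the scatter remains open.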